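The compounds below may be only part of what the source reports. "The series", "measured", "known", "first", "only" and "open" are said of these compounds alone.

The measured compounds:
Compound 1 `Cc1cccc(C)c1-c1cccc(COc2ccc(CCC(=O)O)cn2)c1` gives 3.5 nM in a functional assay on CHO cells for agonist activity at Free fatty acid receptor 1 (Homo sapiens), read by calcium flux; on this read-out lower numbers stand for an effect already at smaller amounts and higher numbers for an effect only at larger amounts of compound.
Compound 2 `CCOC(CC(=O)O)c1ccc(OCc2cccc(-c3c(C)cccc3C)c2)nc1` gives 14 nM in this assay.
Compound 3 `CCOC(CC(=O)O)c1ccc(OCc2ccccc2C)cc1` gives 20 nM in this assay.

Compound 3 has the highest of the three numbers; its gap to compound 2 is within the scatter, while its gap to compound 1 lies beyond it. Compound 4 `CCOC(CC(=O)O)c1ccc(OCc2ccc(C)cc2)cc1` differs from compound 3 by 4-methylphenyl in place of 2-methylphenyl on a saturated chain carbon bound to an oxygen on an aromatic ring. Among the compounds with values here, the only measured step, a 4.0-fold higher number from compound 1 to compound 2 (0.60 log units; beyond the scatter), concerns a different part of the molecule and says nothing about exchanging 2-methylphenyl for 4-methylphenyl, so no measured step bears directly on this change. Without a guide, a modest loss is expected as a cautious guess, a 2.5-fold higher number from compound 3 to compound 4 (0.40 log units; beyond the scatter). Compound 4 is therefore estimated at 50 nM, with a range from 15 nM to 200 nM.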

Compound 4, half-maximal effective concentration in the Free fatty acid receptor 1 assay: 370 nM
For compound 4 the middle estimate is 7.4-fold (0.87 log units) below the measured one, and the stated range ends below it.
By their numbers in the Free fatty acid receptor 1 assay, from the lowest: compound 1; then compounds 2 and 3 (each within the scatter of the next); then compound 4.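

In the Free fatty acid receptor 1 assay compound 3 gives 20 nM and compound 4 gives 370 nM. In the Free fatty acid receptor 1 assay, moving the methyl group from 2-methylphenyl to 4-methylphenyl gives a 19-fold higher number from compound 3 to compound 4 (1.27 log units; beyond the scatter). Within the data shown here, the two groups hold the same atoms, so at this position the placement of a single methyl on the ring is enough for a large change, which the one earlier step, made elsewhere in the molecule, could not show. Nothing available explains the size of this step.

On these data alone, whether a methoxy group or a chlorine in place of the methyl would show the same sensitivity remains open. In a physicochemical assay for lipophilicity, at pH 7.4 (on this read-out lower numbers stand for lower lipophilicity and higher numbers for higher lipophilicity), compound 3 gives 1.2 and compound 4 is entered as "not determined" (no result reported) with no result reported, so this pair offers no comparison.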